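The compounds below may be only part of what the source reports. "The series", "measured", "known", "first", "only" and "open" are said of these compounds alone.

Of the compounds shown here, two sharing one core have been measured in a physicochemical assay for lipophilicity; on this read-out lower numbers stand for lower lipophilicity and higher numbers for higher lipophilicity. Compound 1 `Brc1cccc(Br)c1N(CC1CC1)C1=NCCN1` gives -1.12 in this assay, and compound 2 `C=CCCN(C1=NCCN1)c1c(Br)cccc1Br` gives -0.63. Of these two numbers, compound 2 stands highest. Among the measured compounds shown here, the single measured step, a number 0.49 log units higher from compound 1 to compound 2 (beyond the scatter), comes from putting allyl in place of cyclopropyl on a saturated chain carbon bound to a nitrogen on an aromatic ring.

Compound 3 `Brc1cccc(Br)c1N(Cc1ccco1)C1=NCCN1` has not yet been measured. It differs from compound 2 in one place: furan-2-yl in place of allyl on a saturated chain carbon bound to a nitrogen on an aromatic ring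

For the measured compounds named here, the one measured step concerns a different swap at the same place, so it shows how far a change there can move the number, but it says nothing direct about a furan-2-yl group entering. Going by the values given here, no measured pair carries an aromatic ring into this position, so the direction of the coming step is open: a modest step either way, or none beyond the scatter, would all fit what is known. Compound 3 is therefore expected to give -0.7 in this assay, with a range from -1.3 to -0.1. That expectation amounts to a number 0.07 log units lower from compound 2 to compound 3 (within the scatter).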

Compound 3, distribution coefficient: -0.52
Compound 3: middle estimate off by 0.18 log units, on the low side; measured number inside the range.
By their numbers in this assay, from the lowest: compound 1; then compounds 2 and 3 (each within the scatter of the next).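

Putting furan-2-yl in place of allyl on a saturated chain carbon bound to a nitrogen on an aromatic ring adds a five-membered aromatic ring and a hydrogen-bond acceptor, yet this assay does not separate the two groups: the change reads a number 0.11 log units higher from compound 2 to compound 3 (within the scatter) and is too small to count as a real difference. Measured against cyclopropyl, the same group gives a number 0.60 log units higher from compound 1 to compound 3 (beyond the scatter) and so, among these three compounds, compound 1 is the one that stands apart, while compounds 2 and 3 form a single level despite their different side groups. Nothing available explains why these groups fall where they do.

Three groups at one position cannot show how far the number can move there, and a plain saturated chain such as propyl, a longer chain, an amine or a carboxylic acid could land near compound 1, near compounds 2 and 3, or well away from both. A phenyl ring in the same place would also show whether furan-2-yl is typical of aromatic rings here or a single case.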